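The source may report more compounds than this note shows. Statements on the series, on what has been measured and on what is new or still open speak of the compounds shown alone.

Measured compounds:
- compound 1 `CCOc1ccc(/C=C(\C(=O)c2ccc(Cl)cc2)S(=O)(=O)Cc2ccc(F)cc2)cc1OC` — 50000 nM
- compound 2 `O=C(O)c1ccc(C(=O)/C(=C\c2ccc(Cl)c([N+](=O)[O-])c2)SCc2ccc(C(F)(F)F)cc2)cc1` — 1000 nM
- compound 3 `Cc1ccc(S/C(=C/c2sccc2C)C(=O)c2ccc(Br)cc2)cc1` — 50000 nM

All three have been run in a functional assay on DU-145 cells (Homo sapiens) for inhibition, read by trypan blue exclusion, with a stated time of 96 h; a lower number here means a stronger inhibitor of growth, a higher number a weaker inhibitor of growth. Compound 1 and compound 3 give the same number at the digits recorded, together the highest of the three, with no separation between them within the scatter. Compound 2 stands apart: its number is far lower than that of compound 1, beyond the scatter. Among the compounds with values here, compound 2 differs from compound 1 in several places at once, and no single-point step between any two of the measured compounds is available, so nothing here isolates what drives that gap.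

The next compound to be run is compound 4 `CCOc1ccc(/C=C(\C(=O)c2ccc(Cl)cc2)S(=O)(=O)Cc2ccccc2Cl)cc1OC`. It is built on the core of compound 1 and differs from it in one place only: 2-chlorophenyl in place of 4-fluorophenyl on a saturated chain carbon bound to a sulfonyl sulfur. Within the data shown here, no measured pair shows the effect of such a swap in this assay, so there is no step to lean on. With the rest of compound 1 held unchanged, the expectation is a number close to that of compound 1, a step of a 1.3-fold lower number from compound 1 to compound 4 (0.10 log units; within the scatter) that stays within the scatter or moves little beyond it. Compound 4 is therefore estimated at 40000 nM, with a range from 15000 nM to 60000 nM, and there is a fair chance that the assay returns only a limit rather than a number.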

Compound 4, concentration for 50% growth inhibition: 10000 nM
Estimate against measurement, compound 4: 4.0-fold (0.60 log units) above, outside the stated range (below it).
By their numbers in this assay, from the lowest: compound 2; then compound 4; then compounds 1 and 3 (each within the scatter of the next).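

In this assay, within the data shown here, this is the first single-point reading: 2-chlorophenyl in place of 4-fluorophenyl on a saturated chain carbon bound to a sulfonyl sulfur gives a 5.0-fold lower number from compound 1 to compound 4 (0.70 log units; beyond the scatter). With the rest of the core of compound 1 held unchanged, the position is therefore not silent, since one swap here moves the number beyond the scatter, though the step is modest in size. The outgoing and incoming groups match in heavy-atom count, in their single carbon-only aromatic ring and in their hydrogen-bond donor and acceptor counts, and nothing available explains the step.

Among these compounds, the single step changes the halogen and its place on the ring together, so the two contributions cannot be separated, and how an unsubstituted phenyl or a pyridine ring would read at this place remains open. Among the compounds shown here, also open is whether the same swap carries the same step onto a compound with a sulfide sulfur in place of the sulfonyl, since the series so far offers only this one pair.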